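A nitro group in place of propyl on a benzamide

The compounds below may be only part of what the source reports. "The series", "measured", "known", "first", "only" and "open" are said of these compounds alone.

Among the measured compounds shown here, compound 1 `CCCc1ccc(OCc2ccc(C(=O)Nc3ccccc3N)cc2)cc1` is the only compound here with a number: in a functional assay on A549 cells (Homo sapiens) for antiproliferative activity, read by CCK-8 assay, with a stated time of 72 h (a higher number here means a weaker inhibitor, a lower number a stronger inhibitor), compound 1 gives 5210 nM. Compound 2 `Nc1cnccc1NC(=O)/C=C/c1ccc(COc2ccccc2)cc1` shows no number in this assay; for compound 2 the value > 32000 nM is a limit of the assay (the limit of > 32000 nM in this assay, at which 1 of the 2 values shown sits). For the measured compounds named here, no pair of measured compounds differing in one place is available, so nothing about the shared core can be read from a measured step.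

Compound 3 `Nc1ccccc1NC(=O)c1ccc(COc2ccc([N+](=O)[O-])cc2)cc1` is not yet measured. It differs from compound 1 in one place: nitro in place of propyl on an aromatic carbon. Both compounds share the core of compound 1, and the change sits on the outer aromatic ring.

Going by the values given here, since no measured step shows what this kind of exchange does in this assay, a modest step is expected, most likely within or only slightly beyond the usual scatter, in the direction of a somewhat weaker inhibitor. Compound 3 is therefore estimated at 7000 nM, with a range from 2500 nM to 25000 nM, which corresponds to an expected step of a 1.3-fold higher number from compound 1 to compound 3 (0.13 log units; within the scatter).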

Compound 3, half-maximal inhibitory concentration: > 32000 nM
Compound 3: no number, only a limit (the forecaster's own chance of this, stated with the estimate: 15%); middle value at least 4.5-fold (0.66 log units) away from the limit.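

The exchange of propyl for nitro on the outer aromatic ring, para to a large group, gives an at least 6.1-fold higher number from compound 1 to compound 3 (0.78 log units; beyond the scatter). Among the compounds shown here, this is the first measured evidence that this position matters in this assay: the two groups have the same number of heavy atoms, yet the change carries the compound from a measurable value to a limit, so 4-nitrophenyl cannot stand in for 4-propylphenyl here without a loss beyond the scatter. The true size of the step stays unknown, as the value of compound 3 is a limit of the assay and not a number, and such limits make up much of what is shown: the limit of > 32000 nM in this assay, at which 2 of the 3 values shown sit.

The compounds shown leave open whether the loss comes from the arrival of nitro or from the departure of propyl, a question that a plain hydrogen at this position would address. They also leave open how an amine, a methoxy group or a longer chain such as butyl would fare here, and so whether any other group at this position would match or better compound 1.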